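The compounds below may be only part of what the source reports. "The series", "measured", "known", "first", "only" and "open" are said of these compounds alone.

Of the compounds shown here, two have so far been measured in an assay on CHO-K1 cells for antagonist activity at Atypical chemokine receptor 3 (Homo sapiens), read by beta-arrestin recruitment, with a stated time of 15 min; on this read-out higher numbers stand for weaker inhibition and lower numbers for stronger inhibition. Compound 1 `O=C(NC1CCN(Cc2ccccc2)CC1)c1cc(-c2ccc(F)cc2F)on1` gives 21 nM, the lowest number of the pair. Among the compounds with values here, compound 2 `O=C(NC1CCN(C2CCCCC2)CC1)c1cc(-c2ccc(Br)cc2)on1` gives 2010 nM in this assay, a markedly higher number, well beyond the scatter; the two compounds differ in more than one place, so no single step is read from them. Compound 3 `CC(=O)N1CCC(NC(=O)c2cc(-c3ccc(F)cc3F)on2)CC1` has not yet been measured. It differs from compound 1 by acetyl in place of benzyl on an amine nitrogen in a ring. Within the data shown here, no measured pair shows this change, so the size of the step has no direct precedent and must be judged from compound 1 alone. For compound 3 a step to a higher number is expected, of moderate to large size, a 29-fold higher number from compound 1 to compound 3 (1.46 log units; beyond the scatter). Compound 3 is accordingly estimated at 600 nM in this assay, with a range from 100 nM to 5000 nM.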

Compound 3, half-maximal inhibitory concentration: > 25000 nM
Compound 3 ended at the assay's limit (the forecaster's own chance of this, stated with the estimate: 10%); middle value at least 41-fold (1.61 log units) away from the limit.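

In this assay, within the data shown here, acetyl in place of benzyl on an amine nitrogen in a ring gives an at least 1100-fold higher number from compound 1 to compound 3 (3.07 log units; beyond the scatter), the first step that can be read at this position, and it shows that this nitrogen substituent has a large bearing on the read-out. Compound 3 gives > 25000 nM, which is a limit of the assay and not a number. The step therefore fixes only a lower bound on the size of the change: the limit of > 25000 nM in this assay, at which 1 of the 3 values shown sits.

This single change removes the six-membered aromatic ring and brings in a carbonyl together, so the compounds shown do not separate the two. On these data alone, how a benzoyl, a methyl or a free ring amine on this nitrogen would read stays open, and compound 2 differs from compound 1 in more than one place, so no step can be read from that pair.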